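Notes on amine variation at the saturated ring carbon

This account rests on a few compounds, and the source may have more. Where it says the series, first, only, none or still open, it means among the compounds named here.

Measured so far:
compound 1, `CN(CC1CCN(CCCc2c[nH]c3ccc(-n4cnnc4)cc23)CC1)C(=O)Nc1ccccc1`, gives 5.9 nM in an assay on CHO cells for displacement of a labelled ligand from 5-hydroxytryptamine receptor 1D (Homo sapiens); on this read-out higher numbers stand for weaker inhibition and lower numbers for stronger inhibition
compound 2, `O[C@H]1Cc2ccccc2C1NC1CCN(CCCc2c[nH]c3ccc(-n4cnnc4)cc23)CC1`, gives 37 nM
compound 3, `OC[C@H](NC1CCN(CCCc2c[nH]c3ccc(-n4ccnc4)cc23)CC1)c1ccccc1`, gives 0.7 nM

Among the three, compound 2 gives the highest number in this assay; compound 1 lies lower by a step beyond the scatter, and compound 3 lower still. Compound 4, `CN(Cc1cccs1)C1CCN(CCCc2c[nH]c3ccc(-n4cnnc4)cc23)CC1`, has not been measured. Compared with compound 2 the change is: methyl((thiophen-2-yl)methyl)amino in place of (2-hydroxy-2,3-dihydro-1H-inden-1-yl)amino on a saturated ring carbon. For the measured compounds named here, no pair of measured compounds differs in one place, so the step has to be judged from the spread of the three values, all of which share the same core and differ only at this position. Compound 1 and compound 3 both sit below compound 2, so the step from compound 2 to compound 4 is expected to be a moderate decrease beyond the scatter, a 3.7-fold lower number from compound 2 to compound 4 (0.57 log units; beyond the scatter). For compound 4 the expected value is 10 nM, in the range 2 nM to 60 nM.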

Compound 4, half-maximal inhibitory concentration: 4.3 nM
For compound 4 the middle estimate is 2.3-fold (0.37 log units) above the measured one; low and high end bracket the measured number.
By their numbers in this assay, from the lowest: compound 3; then compounds 4 and 1 (each within the scatter of the next); then compound 2.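

This position tolerates a large change: with methyl((thiophen-2-yl)methyl)amino in place of (2-hydroxy-2,3-dihydro-1H-inden-1-yl)amino, this assay shows an 8.6-fold lower number from compound 2 to compound 4 (0.93 log units; beyond the scatter). Neither the hydroxyl group nor a hydrogen-bond donor in this substituent is therefore needed for a low number on this read-out, at least in the pair read here. No measurement at hand accounts for the step.

Since the ring and the amine substitution change together, their shares remain unresolved. A methyl(benzyl)amino group or a (thiophen-2-yl)methylamino group at this carbon would separate them.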